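Aryl substituent swaps on the amide series: cytotoxicity notes

The source may hold more compounds than are shown below. What is called first, only, known or untested is meant among the compounds shown, and "the series" means these compounds.

Compound 3 `COC(=O)c1cccc(NC(=O)C2CCCN(C(=O)c3cc(C(F)(F)F)cc(C(F)(F)F)c3)C2)c1` carries a methoxycarbonyl group on an aromatic carbon of the shared core. In an ADME assay on PC-3 cells (Homo sapiens) for cytotoxicity, read by WST assay, tested at 100 uM (a higher number here means more inhibition at the concentration tested (going by the name of the read-out), a lower number less inhibition), compound 3 gives 0%. Compound 1 `CSc1cccc(NC(=O)C2CCCN(C(=O)c3cc(C(F)(F)F)cc(C(F)(F)F)c3)C2)c1` gives 0% and compound 2 `CCc1cccc(NC(=O)C2CCCN(C(=O)c3cc(C(F)(F)F)cc(C(F)(F)F)c3)C2)c1` gives 0% in this assay, so compound 3 stands level with both. The three measured steps, no change at the digits printed from compound 1 to compound 2 (within the scatter), no change at the digits printed from compound 1 to compound 3 (within the scatter) and no change at the digits printed from compound 2 to compound 3 (within the scatter), all lie within the scatter; no swap at this aromatic carbon has yet moved the read-out. Compound 4 `O=C(Nc1cccc(Cc2ccccc2)c1)C1CCCN(C(=O)c2cc(C(F)(F)F)cc(C(F)(F)F)c2)C1` is the next member. Relative to compound 3 the change is benzyl in place of methoxycarbonyl on an aromatic carbon. Within the data shown here, a benzyl group has not been tried, so the earlier steps bear on it only as a pattern: every swap at this carbon so far has been flat, with no compound going against it. The step of no change at the digits printed from compound 3 to compound 4 (within the scatter) is therefore expected to be none beyond the scatter. For compound 4 the estimate in this assay is 0%, with a range from -10% to 15%.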

Compound 4, a percentage reported as inhibition, at one concentration (the size of the read-out at that concentration, not a potency): 0%
The estimate for compound 4 equals the measured number at the digits printed; the range from low to high includes it.
By their numbers in this assay, from the lowest: compounds 1, 2, 3 and 4 (each within the scatter of the next).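

Benzyl in place of methoxycarbonyl gives no change at the digits printed from compound 3 to compound 4 (within the scatter) in this assay, and the comparisons with the other two compounds agree: no change at the digits printed from compound 2 to compound 4 (within the scatter) and no change at the digits printed from compound 1 to compound 4 (within the scatter). The flat pattern at this aromatic carbon, which is meta to a large group, now extends across all four compounds with none against it, and it holds when a group of 7 heavy atoms with one six-membered aromatic ring of carbon only and no hydrogen-bond acceptors replaces one of 4 heavy atoms with 2 hydrogen-bond acceptors. No supporting data explain why the read-out stays level across these swaps.

As far as these compounds go, whether an amine, a carboxylic acid or a longer alkyl chain on this carbon would shift the read-out remains open. The compounds shown also leave open whether any group here can move the read-out in this cell assay at all.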